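The compounds below may be only part of what the source reports. "The series", "measured", "known", "first", "only" and "open" are said of these compounds alone.

Working notes on the series. Compound 1 `COc1cc2c(Nc3nc4ccc(C(=O)Nc5c(C)cc(C)cc5C)cc4s3)ncnc2cc1OCCCN1CCC(C)CC1` has been run in a functional assay on K562 cells (Homo sapiens) for cytotoxicity, read by WST assay, with a stated time of 72 h (a higher number here means a weaker inhibitor, a lower number a stronger inhibitor), and compound 1 gives 5900 nM. Compound 2 `COc1cc2c(Nc3nc4ccc(C(=O)Nc5c(C)cccc5C)cc4s3)ncnc2cc1OCCCN1CCCCC1` in this assay gives 13700 nM. Compound 1 therefore stands lowest of the two numbers in hand, and the gap to compound 2 lies beyond the usual scatter. Among the measured compounds shown here, compound 2 differs from compound 1 in more than one place, so no single step between them can be isolated; the two values are simply what each compound shows.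

Compound 3 `CCN(CC)CCCOc1cc2ncnc(Nc3nc4ccc(C(=O)Nc5c(C)cc(C)cc5C)cc4s3)c2cc1OC` has not yet been measured in this assay. It differs from compound 1 in one place: diethylamino in place of 4-methylpiperidin-1-yl on a saturated chain carbon, three bonds along the chain from an oxygen on an aromatic ring. For the measured compounds named here, no pair of measured compounds isolates this change, and the amide end of the molecule is left untouched. With nothing in the measured pair to point either way, the step expected a 1.2-fold higher number from compound 1 to compound 3 (0.07 log units; within the scatter) is small, not beyond the scatter in either direction. Compound 3 is accordingly expected to give 7000 nM in this assay, with a range from 3000 nM to 17000 nM.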

Compound 3, half-maximal inhibitory concentration: 6800 nM
The estimate for compound 3 lay 1.0-fold (0.01 log units) above the measured number, within the range that was stated.
By their numbers in this assay, from the lowest: compounds 1, 3 and 2 (each within the scatter of the next, the first and the last beyond it).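

In this assay, diethylamino in place of 4-methylpiperidin-1-yl on a saturated chain carbon, three bonds along the chain from an oxygen on an aromatic ring, gives a 1.2-fold higher number from compound 1 to compound 3 (0.06 log units; within the scatter). Among the compounds shown here, this is the first change that can be read in a single place, and it shows that, with the rest of the molecule held fixed, an open diethylamino group and the six-membered 4-methylpiperidin-1-yl ring cannot be told apart at this position in this assay. No measurement shown accounts for this result, so it stands without an explanation.

The compounds shown do not tell whether the same holds for a morpholin-4-yl group, a piperazin-1-yl group, a smaller dimethylamino group or a carboxylic acid at the end of the chain, any of which would test this place more widely than two tertiary amines of similar make-up. They also leave open how a longer chain, such as 4-(diethylamino)butyl in place of 3-(diethylamino)propyl, would read, and whether the diethylamino result carries over to a different group at the amide end.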